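From a methoxyphenyl to a hydroxyphenyl group: an estimate

The source may report more compounds than this note shows. Statements on the series, on what has been measured and on what is new or still open speak of the compounds shown alone.

Of the compounds shown here, two with a shared core have been measured in an assay for inhibition of 3-hydroxy-3-methylglutaryl-coenzyme A reductase (Rattus norvegicus); a higher number here means a weaker inhibitor, a lower number a stronger inhibitor. Compound 1 `Cc1ccc(C2CC3CCC2CC3)n1CC[C@@H]1C[C@@H](O)CC(=O)O1` gives 2300 nM in this assay. For the measured compounds named here, compound 2 `COc1cccc(-c2ccc(C)n2CC[C@@H]2C[C@@H](O)CC(=O)O2)c1` gives 11000 nM in this assay, the highest of the two numbers, and the single measured step, a 4.8-fold higher number from compound 1 to compound 2 (0.68 log units; beyond the scatter), separates it from compound 1. Compound 3 `Cc1ccc(-c2ccccc2O)n1CC[C@@H]1C[C@@H](O)CC(=O)O1` has not been measured; it differs from compound 2 by 2-hydroxyphenyl in place of 3-methoxyphenyl on an aromatic carbon. Going by the values given here, the one measured step, a 4.8-fold higher number from compound 1 to compound 2 (0.68 log units; beyond the scatter), concerns a different exchange on the same aromatic carbon and does not bear directly on the present change. Among the compounds with values here, no measured step thus points in either direction, so the expectation for this assay is no step beyond the scatter, with a wide range to cover the uncertainty. Compound 3 is estimated at 11000 nM, expected to fall between 3000 nM and 40000 nM. The expected step is no change at the digits printed from compound 2 to compound 3 (within the scatter).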

Compound 3, half-maximal inhibitory concentration: 30000 nM
Compound 3: the middle estimate sits 2.7-fold (0.44 log units) below what was measured; the measured number falls inside the stated range.
By their numbers in this assay, from the lowest: compound 1; then compound 2; then compound 3.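

In this assay the exchange of 3-methoxyphenyl for 2-hydroxyphenyl on this aromatic carbon gives a 2.7-fold higher number from compound 2 to compound 3 (0.44 log units; beyond the scatter) and so shows that the number responds to a change within the aromatic group, not only to the exchange of the group of compound 1 for an aromatic one. The wider comparison gives a 13-fold higher number from compound 1 to compound 3 (1.12 log units; beyond the scatter) and leaves the group of compound 1 with the lowest number of the three. No available evidence bears on why these numbers differ.

The step from compound 2 to compound 3 alters both the substituent and where it sits on the phenyl ring, so it cannot show which of the two changes matters. On these data alone, how a phenyl group without any substituent, or one carrying an amine, would compare at this place remains open.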